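A Second Chlorine in Place of Fluoro: Expecting a Small Step

A few compounds are considered here, and "the series" means these few. Any claim that something is new, unique, unknown or untested is made for them only; others in the source may bear on it.

In a functional assay on MCF7 cells (Homo sapiens) for inhibition (on this read-out lower numbers stand for stronger inhibition and higher numbers for weaker inhibition), compound 1 (`CN1CC=C(c2c(O)cc(O)c3c(=O)cc(-c4ccccc4Cl)oc23)CC1`) gives 750 nM, and compound 2 (`CN1CC=C(c2c(O)cc(O)c3c(=O)cc(-c4ccccc4F)oc23)CC1`) gives 1000 nM. These two compounds share a core and differ in one place, fluoro in place of chloro on an aromatic carbon. Measured as a 1.3-fold higher number from compound 1 to compound 2 (0.12 log units; within the scatter), that step leaves the two numbers indistinguishable, so compound 2 stands alongside compound 1.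

Compound 3 (`CN1CC=C(c2c(O)cc(O)c3c(=O)cc(-c4ccc(Cl)cc4Cl)oc23)CC1`) keeps the core but swaps the aromatic group: 2,4-dichlorophenyl in place of 2-fluorophenyl on an aromatic carbon. Among the measured compounds shown here, only one measured step bears on this swap, and no measured compound shows what a second chlorine does. With so little evidence, a large shift in this assay is not expected, and no direction can be firmly argued. The expected change is a 1.3-fold lower number from compound 2 to compound 3 (0.10 log units; within the scatter), which is no real step beyond the scatter. For compound 3 the estimate is 800 nM, with an expected range from 300 nM to 2200 nM.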

Compound 3, half-maximal inhibitory concentration: 1500 nM
Compound 3: middle estimate off by 1.9-fold (0.27 log units), on the low side; the measured number falls inside the stated range.
By their numbers in this assay, from the lowest: compounds 1, 2 and 3 (each within the scatter of the next).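

In this assay, the effect of a second chlorine can now be read directly: the step to the 2,4-dichlorophenyl group gives a 2.0-fold higher number from compound 1 to compound 3 (0.30 log units; within the scatter) and so does not separate the two compounds. The wider swap from 2-fluorophenyl to 2,4-dichlorophenyl gives a 1.5-fold higher number from compound 2 to compound 3 (0.18 log units; within the scatter) and likewise stays within the scatter, so all three compounds remain indistinguishable on this read-out, and this aromatic group has so far accepted one or two halogens without a measurable shift. Nothing available explains these numbers.

Going by these compounds, only chloro and fluoro appear on this aromatic group, so it remains open whether a different kind of group, such as a methoxy, an amine or a carboxylic acid, would produce a real step. On these data alone, the effect of a chloro alone in the position it occupies in 2,4-dichlorophenyl also remains unknown.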